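A few compounds are considered here, and "the series" means these few. Any claim that something is new, unique, unknown or untested is made for them only; others in the source may bear on it.

Measured so far in this series:
compound 1 `O=c1[nH]c(-c2ccccc2O)nc2c1cnn2-c1ccccc1`: 93%
compound 2 `CCCOc1ccccc1-c1nc2c(cnn2-c2ccccc2)c(=O)[nH]1`: 150%
compound 3 `O=c1[nH]c(-c2ccccc2O)nc2c1cnn2-c1ccc(Br)cc1`: 167%

In a functional assay on corpus cavernosum (Rattus norvegicus) for activation (on this read-out higher numbers stand for larger maximal responses and lower numbers for smaller maximal responses), compound 3 gives 167% and stands highest of the three numbers. Compound 2 gives 150%, and compound 1 gives 93%, so compound 1 is the lowest of the set, with both other compounds beyond the scatter above it.

Compound 4 `CCCOc1ccccc1-c1nc2c(cnn2-c2ccc(Br)cc2)c(=O)[nH]1` is reached from compound 3 by one change: propyl in place of hydrogen on an oxygen on an aromatic ring. The same change has been measured once, on the unsubstituted phenyl: a number 57 percentage points higher from compound 1 to compound 2 (beyond the scatter). The bromo change, measured on the same parent, gave a number 74 percentage points higher from compound 1 to compound 3 (beyond the scatter), and compound 4 carries both changes together. Whether the two add fully is not known from these three compounds; the expectation is a rise in this assay, of a size comparable to but not necessarily as large as the earlier propyl step, since compound 3 already lies high. The expected step is a number 33 percentage points higher from compound 3 to compound 4 (beyond the scatter). For compound 4 the estimate is 200%, with a range from 155% to 245%.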

Compound 4, largest response reached (Emax), in percent of the reference or control that the assay uses: 140%
Beside the measured number, compound 4's estimate is 60 percentage points above it; the whole stated range lies above it.
By their numbers in this assay, from the lowest: compound 1; then compounds 4 and 2 (each within the scatter of the next); then compound 3.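

In this assay, hydroxy to propoxy has no fixed direction on these cores: with the bromo group present, the step is a number 27 percentage points lower from compound 3 to compound 4 (beyond the scatter), against the rise on the unsubstituted phenyl: the same change on two cores in this assay, a number 57 percentage points higher (beyond the scatter) from compound 1 to compound 2 and a number 27 percentage points lower (beyond the scatter) from compound 3 to compound 4, 84 percentage points apart, beyond the scatter of two such steps

The bromo change likewise depends on its partner, giving a number 10 percentage points lower from compound 2 to compound 4 (within the scatter) when propyl is present, so its rise is seen only on the hydroxy parent: the same change on two cores in this assay, a number 74 percentage points higher (beyond the scatter) from compound 1 to compound 3 and a number 10 percentage points lower (within the scatter) from compound 2 to compound 4, 84 percentage points apart, beyond the scatter of two such steps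

The two changes therefore do not add in this set of four compounds.

Going by these compounds alone, with only one pair for each change, it remains open whether this reversal is specific to propyl or would also appear with methyl or a longer chain such as butyl on the same oxygen. Going by these compounds, it is also open whether chloro in place of bromo on the aromatic carbon would behave in the same way.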